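The source may report more compounds than this note shows. Statements on the series, on what has been measured and on what is new or still open speak of the compounds shown alone.

Of the compounds shown here, three with the same extended aromatic framework have been tested in a functional assay on SiHa cells (Homo sapiens) for inhibition, read by sulforhodamine B assay; on this read-out higher numbers stand for weaker inhibition of growth and lower numbers for stronger inhibition of growth. Compound 1 `COc1ccc(-c2ccc(-c3ccc(-c4nc5ccccc5[nH]4)cc3)cc2)cc1OC` gives 6200 nM, compound 2 `Oc1cccc2[nH]c(-c3ccc(-c4ccc(-c5ccc(OC(F)(F)F)cc5)cc4)cc3)nc12` gives 8410 nM, and compound 3 `COc1ccc(-c2ccc(-c3ccc(-c4nc5c(O)cccc5[nH]4)cc3)cc2)cc1` gives 4800 nM. Compound 3 therefore stands within the usual scatter of both other compounds, so the three values cannot be separated.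

Compound 4 `COc1ccc(-c2ccc(-c3ccc(-c4nc5c(O)cccc5[nH]4)cc3)cc2)cc1OC` is derived from compound 3 by one change, methoxy in place of hydrogen on an aromatic carbon, which turns 4-methoxyphenyl into 3,4-dimethoxyphenyl. Among the compounds with values here, no measured step shows this exact change. The closest evidence is a 1.8-fold lower number from compound 2 to compound 3 (0.24 log units; within the scatter), which places methyl in place of trifluoromethyl on an oxygen on an aromatic ring, at the same end of the molecule. That substitution leaves the number within the scatter. The 3,4-dimethoxyphenyl group is also present on a core lacking the hydroxyl group of compound 3, and there compound 1 reads 6200 nM, again within the scatter of compound 3.

On this evidence, no shift beyond the scatter is expected, and the expected change is a 1.1-fold higher number from compound 3 to compound 4 (0.03 log units; within the scatter). The expected value for compound 4 is 5200 nM, with an estimated range of 2600 nM to 10000 nM.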

Compound 4, concentration for 50% growth inhibition: 1110 nM
Beside the measured number, compound 4's estimate is 4.7-fold (0.67 log units) above it, outside the stated range (below it).
By their numbers in this assay, from the lowest: compound 4; then compounds 3, 1 and 2 (each within the scatter of the next).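

In this assay, within the data shown here, the methoxy that turns 4-methoxyphenyl into 3,4-dimethoxyphenyl, placed ortho to a methoxy group and meta to a large group, gives a 4.3-fold lower number from compound 3 to compound 4 (0.64 log units; beyond the scatter), the first step at this end of the molecule to go beyond the scatter. On the same hydroxy-bearing core, replacing 4-(trifluoromethoxy)phenyl with 3,4-dimethoxyphenyl gives a 7.6-fold lower number from compound 2 to compound 4 (0.88 log units; beyond the scatter), while adding the hydroxy to the core while keeping 3,4-dimethoxyphenyl gives a 5.6-fold lower number from compound 1 to compound 4 (0.75 log units; beyond the scatter), so compound 4 loses ground in this assay if either the added methoxy or the hydroxy is taken away. Nothing available here explains why this added methoxy has such an effect. On these data alone, it remains open whether the gain is specific to methoxy at this place, or whether ethoxy, a chlorine atom or an amine there would give a similar number. It also remains open whether the hydroxy on the core would give a step of similar size with 4-methoxyphenyl at the far end, as the compounds shown offer that comparison only with 3,4-dimethoxyphenyl.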